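Swapping One Pyrazole for Another on the Shared Core

The source may report more compounds than this note shows. Statements on the series, on what has been measured and on what is new or still open speak of the compounds shown alone.

Measured and pending compounds in a functional assay on PC-3 cells (Homo sapiens) for antiproliferative activity, read by CCK-8 assay, with a stated time of 6 days; on this read-out lower numbers stand for stronger inhibition and higher numbers for weaker inhibition:
- compound 1 `CCN(c1ccc(C#N)c(Cl)c1)c1cc(-c2cnc3ccccc3c2)ccc1C`: 3570 nM
- compound 2 `CCN(c1ccc(C#N)c(Cl)c1)c1cc(-c2ccco2)ccc1C`: > 30000 nM
- compound 3 `CCN(c1ccc(C#N)c(Cl)c1)c1cc(-c2ccnn2C)ccc1C`: 7290 nM
- compound 4 `CCN(c1ccc(C#N)c(Cl)c1)c1cc(-c2cn[nH]c2)ccc1C`: not yet measured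

The entry for compound 2 is a limit of the assay and not a number, as the limit of > 30000 nM in this assay, at which 1 of the 3 values shown sits, records. That leaves two true numbers in this assay. Compound 3 at 7290 nM holds the higher of them, and compound 1 stands at 3570 nM, a gap just beyond the usual scatter.

The next step is 1H-pyrazol-4-yl in place of 1-methyl-1H-pyrazol-5-yl on an aromatic carbon. In words, it places 1H-pyrazol-4-yl in place of 1-methyl-1H-pyrazol-5-yl on an aromatic carbon. For the measured compounds named here, only one measured step bears on this change: an at least 4.1-fold lower number from compound 2 to compound 3 (0.61 log units; beyond the scatter), which lies beyond the scatter. That step shows that the group at this place can move the number, and it brought in the 1-methyl-1H-pyrazol-5-yl group that now leaves. However, it started from a furan-2-yl compound, and no measured pair exchanges one pyrazole for another. No clear direction can therefore be drawn from it, and the expectation stays close to compound 3. The expected change is a 1.2-fold lower number from compound 3 to compound 4 (0.08 log units; within the scatter), which would not stand beyond the scatter. The estimate for compound 4 is 6000 nM, with an expected range from 2000 nM to 20000 nM.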

Compound 4, half-maximal inhibitory concentration: 15300 nM
Estimate against measurement, compound 4: 2.6-fold (0.41 log units) below; measured number inside the range.
By their numbers in this assay, from the lowest: compound 1; then compound 3; then compound 4. At a limit, above all of these: compound 2.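

In this assay, the exchange of one pyrazole for another gives a 2.1-fold higher number from compound 3 to compound 4 (0.32 log units; beyond the scatter), so this position separates two groups of the same ring type and not only a pyrazole from furan-2-yl. The change is not a single one, however: as their names show, 1H-pyrazol-4-yl differs from 1-methyl-1H-pyrazol-5-yl both in the methyl group and in the ring position through which it is attached, and this step cannot tell those two differences apart. The comparison with the furan-2-yl group gives an at least 1.9-fold lower number from compound 2 to compound 4 (0.29 log units; that floor lies within the scatter), so it does not firmly place the two groups relative to each other, and it rests on a limit of the assay and not a number: the limit of > 30000 nM in this assay, at which 1 of the 4 values shown sits.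

The compounds shown leave open whether the higher number of compound 4 goes with the missing methyl group or with the point of attachment, a question that 1-methyl-1H-pyrazol-4-yl on the shared core would address directly. They also leave open how this place responds to groups outside the five-membered aromatic rings and the fused ring system of compound 1, such as an amine or a carboxylic acid.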